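Removing a methyl from an amine-linked pyridine inhibitor

The compounds below may be only part of what the source reports. "The series", "measured", "known", "first", "only" and "open" are said of these compounds alone.

Measured compounds:
Compound 1 `O=C(Nc1cccc(-c2cccc(O)c2F)n1)c1ccc(F)c(O)c1` gives 686 nM.
Compound 2 `CN(C(=O)c1ccc(F)c(O)c1)c1cccc(-c2cccc(O)c2F)n1` gives 2030 nM.
Compound 3 `CN(c1ccc(F)c(O)c1)c1cccc(-c2cccc(O)c2F)n1` gives 42 nM.

All three were tested in an assay for binding affinity to 17-beta-hydroxysteroid dehydrogenase 14 (Homo sapiens), read by fluorescence, with a stated time of 15 min, in the presence of a further agent that is not named here; a higher number here means a weaker inhibitor, a lower number a stronger inhibitor. Compound 3 gives the lowest number; the difference between the core of compound 3 and the core of compound 2 is not broken down here. Compound 4 `Oc1cc(Nc2cccc(-c3cccc(O)c3F)n2)ccc1F` has not yet been measured. It differs from compound 3 by hydrogen in place of methyl on a nitrogen on an aromatic ring. The same kind of change, (hydrogen in place of methyl on an amide-type nitrogen), gave a 3.0-fold lower number from compound 2 to compound 1 (0.47 log units; beyond the scatter), although there the place was an amide-type nitrogen whose other neighbours are aromatic carbon and carbonyl carbon, whereas in compound 4 the nitrogen is on an aromatic ring with two aromatic carbon neighbours. On that single earlier step, a similar or somewhat smaller change is expected: a 1.7-fold lower number from compound 3 to compound 4 (0.23 log units; within the scatter). Compound 4 is therefore estimated at 25 nM, between 8 nM and 80 nM.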

Compound 4, inhibition constant in the 17-beta-hydroxysteroid dehydrogenase 14 assay: 47 nM
For compound 4 the middle estimate is 1.9-fold (0.27 log units) below the measured one; low and high end bracket the measured number.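

In the 17-beta-hydroxysteroid dehydrogenase 14 assay, hydrogen in place of methyl on a nitrogen on an aromatic ring gives a 1.1-fold higher number from compound 3 to compound 4 (0.05 log units; within the scatter), so the size of this step did not carry over from the pair with the amide-type nitrogen: the same change on two cores in the 17-beta-hydroxysteroid dehydrogenase 14 assay, a 3.0-fold lower number (0.47 log units; beyond the scatter) from compound 2 to compound 1 and a 1.1-fold higher number (0.05 log units; within the scatter) from compound 3 to compound 4, 3.3-fold (0.52 log units) apart, beyond the scatter of two such steps

These two pairs show that the same change can give different steps on different cores in this series, but they do not show what sets the gap or predict the step on a third core. In a physicochemical assay for solubility, in phosphate buffer, with a stated time of 24 h, at pH 7.4, tested at 200 uM (a lower number here means a less soluble compound, a higher number a more soluble compound), compound 3 gives > 200000 nM and this is a limit of the assay. In the physicochemical assay compound 4 gives > 200000 nM and this is also a limit of the assay. In the physicochemical assay the step cannot be read, since the values of both compounds are limits of the assay: the limit of > 200000 nM in the physicochemical assay, at which 2 of the 2 values shown sit.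

As far as these compounds go, what remains open is how an ethyl group or a longer chain on this nitrogen would compare with methyl and hydrogen. From the compounds shown here alone, it is also open whether an amine in such a chain would change the picture.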